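The source may report more compounds than this note shows. Statements on the series, on what has been measured and on what is new or still open speak of the compounds shown alone.

In a functional assay on P388 cells (Mus musculus) for inhibition (a lower number here means a stronger inhibitor, a higher number a weaker inhibitor), compound 1 `O=C1/C(=C/c2cccc(Br)c2)CCCc2ccccc21` gives 10500 nM. Compound 2 `O=C1CCCCC/C1=C\c1cccc(F)c1` has no exact number, only a limit of the assay, > 50000 nM. Compound 3 `Cc1cccc(/C=C2\CCCCCC2=O)c1` has methyl in place of fluoro on an aromatic carbon. Within the data shown here, no measured pair of compounds shows what this swap does. The expected a number no higher from compound 2 to compound 3 (the limit leaves the size open) is therefore no larger than the usual scatter, in either direction. For compound 3, the estimated value is 50000 nM, with an expected range of 20000 nM to 120000 nM.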

Compound 3, half-maximal inhibitory concentration: 29800 nM
Compound 3: the middle estimate sits 1.7-fold (0.22 log units) above what was measured; the measured number falls inside the stated range.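

In this assay, methyl in place of fluoro on an aromatic carbon gives an at least 1.6-fold lower number from compound 2 to compound 3 (0.22 log units; that floor lies within the scatter). Among these compounds, compound 3 therefore provides the first exact number for this position on the core of compound 2, showing that a methyl group here still allows a reading inside the assay's range. Compound 2 has only a limit of the assay, so the true size of the step stays open: the limit of > 50000 nM in this assay, at which 1 of the 3 values shown sits.

As far as these compounds go, what an amine or a carboxylic acid on this same aromatic carbon would give remains open. Compound 1 differs from compound 3 in more than one place, so it cannot settle this.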